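The compounds below may be only part of what the source reports. "The series", "measured", "known", "first", "only" and "open" are said of these compounds alone.

Measured in a functional assay on SK-MEL-5 cells (Homo sapiens) for cytotoxicity, read by sulforhodamine B assay, with a stated time of 48 h; a lower number here means a stronger inhibitor of growth, a higher number a weaker inhibitor of growth:
compound 1 `Nc1nc(Cl)c2ncn(Cc3ccc(CCl)cc3)c2n1` gives 31000 nM
compound 2 `ClCc1ccccc1Cn1cnc2nc(Cl)nc(Cl)c21` gives 2180 nM
compound 3 `ClCc1ccc(Cn2cnc3c(Cl)nc(Cl)nc32)cc1` gives 19100 nM

Compound 2 stands lowest of the three numbers in this assay; its gaps to compound 3 and to compound 1 both lie beyond the scatter, so on the numbers shown it is the strongest inhibitor of growth in this set. Compound 4 `ClCc1ccccc1Cn1cnc2ncnc(Cl)c21` differs from compound 2 in one place: hydrogen in place of chloro on an aromatic carbon.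

Among the measured compounds shown here, the only measured step, a 1.6-fold lower number from compound 1 to compound 3 (0.21 log units; within the scatter), concerns the same place of the shared core, the aromatic carbon between two ring nitrogen atoms, and falls within the scatter. The exchange there was chloro for amino rather than hydrogen for chloro, so it bears on compound 4 only loosely, but it suggests that what sits at this place has not so far moved the numbers. For the measured compounds named here, no measured step covers the loss of a chloro to hydrogen anywhere.

For compound 4 the expectation is therefore a step from compound 2 no larger than the scatter, a 1.5-fold higher number from compound 2 to compound 4 (0.17 log units; within the scatter), leaning if at all toward a higher number. The estimate for compound 4 in this assay is 3200 nM, within 1200 nM to 9000 nM.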

Compound 4, concentration for total growth inhibition: 4070 nM
For compound 4 the middle estimate is 1.3-fold (0.10 log units) below the measured one, within the range that was stated.
By their numbers in this assay, from the lowest: compounds 2 and 4 (each within the scatter of the next); then compounds 3 and 1 (each within the scatter of the next).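

In this assay, among the compounds shown here, the exchange of chloro for hydrogen on the aromatic carbon between two ring nitrogen atoms gives a 1.9-fold higher number from compound 2 to compound 4 (0.27 log units; within the scatter) and is the first step in which this place loses its substituent altogether. Chloro is therefore not required at this place for a compound to stay within the scatter of compound 2, and with a 1.6-fold lower number from compound 1 to compound 3 (0.21 log units; within the scatter) as the second step here, neither exchange at this place moves the number beyond the scatter, although the two steps stand on compounds that carry the chloromethyl group at different places. No evidence bearing on the cause of this result is available.

Still open, from the compounds shown here alone, is whether this tolerance extends to groups of another kind at this place, such as a methoxy group or a longer chain, and whether it holds when the chloromethyl group sits as in compound 1 and compound 3. The compounds shown also leave open what the other chloro group, shared by compound 2 and compound 4, and the chloromethyl group contribute, since neither is exchanged in any step, for instance for an amine or a methyl group.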